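This account rests on a few compounds, and the source may have more. Where it says the series, first, only, none or still open, it means among the compounds named here.

Measured compounds in a functional assay on NIH3T3 cells (Mus musculus); a lower number here means that less compound is needed, a higher number that more compound is needed for the effect:

Compound 1 `N#Cc1ccc(Cn2cncc2CNc2ccc(C(=O)Nc3cccc(C#N)c3)c(-c3ccccc3)c2)cc1` — in this assay compound 1 gives > 10 uM, a limit of the assay rather than a number.
Compound 2 `COC(=O)[C@H](CCSC)NC(=O)c1ccc(NCc2cncn2Cc2ccc(C#N)cc2)cc1-c1ccccc1` — in this assay compound 2 gives > 10 uM, again only a limit.
Compound 3 `N#CCNC(=O)c1ccc(NCc2cncn2Cc2ccc(C#N)cc2)cc1-c1ccccc1` — in this assay compound 3 gives > 10 uM, also a limit.

All three values sit at the same place: the limit of > 10 uM in this assay, at which 3 of the 3 values shown sit. Compound 3 therefore stands nowhere in particular among them; it is indistinguishable from compound 1 and compound 2 on what is shown. The steps among the measured compounds read a step that the two limits leave unreadable from compound 1 to compound 2, a step that the two limits leave unreadable from compound 1 to compound 3 and a step that the two limits leave unreadable from compound 2 to compound 3, so none of them yields a size.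

Compound 4 `CSCNC(=O)c1ccc(NCc2cncn2Cc2ccc(C#N)cc2)cc1-c1ccccc1` differs from compound 3 by methylsulfanyl in place of cyano on a saturated chain carbon bound to an amide-type nitrogen. For the measured compounds named here, no measured step bears readably on this change, and every amide-nitrogen substituent tried so far has left the compound at the limit. The expectation for compound 4 is therefore that this assay will most likely again report only a limit, with the step from compound 3 to compound 4 estimated as a step that the limit leaves unreadable from compound 3 to compound 4. Compound 4 is estimated at 25 uM, within a range from 5 uM to 150 uM.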

Compound 4, concentration for half-maximal effect: > 10 uM
Compound 4 gave a limit, no number; the forecaster's own chance of this, stated with the estimate: 75%; the middle value does not contradict the limit.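

In this assay, for the compounds shown here, compound 4 gives > 10 uM as a limit and not a number, and no step linking it to compound 1, compound 2 or compound 3 can be read. The compounds shown leave open whether any substituent on the amide-type nitrogen brings a readable value.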